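The source may hold more compounds than are shown below. What is called first, only, known or untested is meant among the compounds shown, and "the series" means these compounds.

Of the compounds shown here, three built on one shared core have been tested in an assay for binding affinity to dual specificity mitogen-activated protein kinase kinase 4 (Homo sapiens), read by KINOMEscan, tested at 100 nM; a lower number here means a stronger effect, a higher number a weaker effect of the compound at the concentration tested. Compound 1 `CCCS(=O)(=O)Nc1ccc(F)c(C(=O)c2n[nH]c3ncc(-c4ccccc4OC)cc23)c1F` gives 1.9%, compound 2 `CCCS(=O)(=O)Nc1ccc(F)c(C(=O)c2n[nH]c3ncc(-c4ccccc4O)cc23)c1F` gives 9%, and compound 3 `CCCS(=O)(=O)Nc1ccc(F)c(C(=O)c2n[nH]c3ncc(-c4cccc(N(C)C)c4)cc23)c1F` gives 26%. Compound 3 stands highest of the three numbers, so it shows the weakest effect at the concentration tested; the step of a number 17 percentage points higher from compound 2 to compound 3 (beyond the scatter) lies beyond the scatter, as does the step of a number 24.1 percentage points higher from compound 1 to compound 3 (beyond the scatter). By contrast the step of a number 7.1 percentage points higher from compound 1 to compound 2 (within the scatter) stays within the scatter.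

Compound 4 `CCCS(=O)(=O)Nc1ccc(F)c(C(=O)c2n[nH]c3ncc(-c4ccc(-c5nnn[nH]5)cc4)cc23)c1F` has not yet been measured. 4-(1H-tetrazol-5-yl)phenyl in place of 3-(dimethylamino)phenyl on an aromatic carbon The two measured steps that exchange the whole aryl group, a number 24.1 percentage points higher from compound 1 to compound 3 (beyond the scatter) and a number 17 percentage points higher from compound 2 to compound 3 (beyond the scatter), were both modest and both ended at compound 3 with a higher number. A further exchange of the same group is therefore expected to move the number by a modest amount, most likely downward from compound 3, by a number 11 percentage points lower from compound 3 to compound 4 (beyond the scatter). The estimate for compound 4 is 15%, with a range from 3% to 50%.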

Compound 4, a percentage reported as activity, at one concentration (the size of the read-out at that concentration, not a potency): 0.15%
Compound 4: the middle estimate sits 14.9 percentage points above what was measured; the whole stated range lies above it.
By their numbers in this assay, from the lowest: compounds 4, 1 and 2 (each within the scatter of the next); then compound 3.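

In this assay, the change to 4-(1H-tetrazol-5-yl)phenyl gives a number 25.9 percentage points lower from compound 3 to compound 4 (beyond the scatter), so this aromatic carbon of the shared core can carry a group with a second ring, one five-membered with 4 hetero atoms, and the higher number of compound 3 does not extend to this larger group. The other two steps, a number 8.9 percentage points lower from compound 2 to compound 4 (within the scatter) and a number 1.8 percentage points lower from compound 1 to compound 4 (within the scatter), place compound 4 level with both earlier compounds, so three quite different aryl groups cannot be told apart at this single concentration. Nothing available explains the difference from compound 3.

From the compounds shown here alone, it remains open whether the tetrazole ring itself matters or only the phenyl ring that carries it, and whether a carboxylic acid on that phenyl ring would serve equally. Separating compounds 1, 2 and 4 would need a read-out other than the size of the effect at this single concentration.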